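Swapping a methylphenyl for a dichlorophenyl in a cytotoxic series

The source may hold more compounds than are shown below. What is called first, only, known or untested is meant among the compounds shown, and "the series" means these compounds.

Compound 1 `C=CCn1c(=O)/c(=C\c2cccc(C)c2)[nH]c(=O)/c1=C\c1ccccc1OC`: 16000 nM
Compound 2 `C=CCn1c(=O)/c(=C\c2ccc(F)c(Br)c2)[nH]c(=O)/c1=C\c1ccccc1OC`: "not active" (no number reported)
Compound 3 `C=CCn1c(=O)/c(=C\c2ccc(Cl)c(Cl)c2)[nH]c(=O)/c1=C\c1ccccc1OC`: "not active" (no number reported)

Among the measured compounds shown here, in a functional assay on MOLT-4 cells (Homo sapiens) for cytotoxicity, read by CCK-8 assay, with a stated time of 72 h (a higher number here means a weaker inhibitor, a lower number a stronger inhibitor), compound 1 gives 16000 nM, the only number reported in this set. Compound 2 and compound 3 return no number at all, each reported as inactive. Compound 4 `C=CCn1c(=O)/c(=C\c2cccc(Cl)c2Cl)[nH]c(=O)/c1=C\c1ccccc1OC` has not been measured. It differs from compound 1 by 2,3-dichlorophenyl in place of 3-methylphenyl on a double-bonded chain carbon bound to an aromatic carbon. Compound 2 and compound 3 also carry two halogens on this ring and show no activity, so a move to a weaker or unmeasurable result seems more likely than an improvement. The step from compound 1 to compound 4 is expected to be a loss of potency beyond the scatter, a 2.8-fold higher number from compound 1 to compound 4 (0.45 log units; beyond the scatter). Compound 4 is therefore estimated at 45000 nM, within 15000 nM to 150000 nM.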

Compound 4, half-maximal inhibitory concentration: 1200 nM
The estimate for compound 4 lay 38-fold (1.57 log units) above the measured number, outside the stated range (below it).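

Replacing 3-methylphenyl with 2,3-dichlorophenyl in this assay gives a 13-fold lower number from compound 1 to compound 4 (1.12 log units; beyond the scatter) and shows that this ring can carry two chlorines and still gain potency. Two halogens on the ring therefore do not by themselves remove activity, since compound 3 also has two chlorines yet is reported as not active, which points to their arrangement mattering among these compounds. Nothing available here explains the gain.

From the compounds shown here alone, it remains open whether one chlorine alone would give the same gain. Whether an amine or a carboxylic acid on this ring would be tolerated is also unresolved.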